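The compounds below may be only part of what the source reports. "The series", "measured", "known", "first", "only" and "open" are said of these compounds alone.

Measured so far in a functional assay on SiHa cells (Homo sapiens) for inhibition, read by sulforhodamine B assay; a lower number here means a stronger inhibitor of growth, a higher number a weaker inhibitor of growth
- compound 1 `Cc1ccc2[nH]c(-c3ccc(-c4ccc(-c5ccc(N(C)C)cc5)cc4)cc3)nc2c1` gives 7110 nM
- compound 2 `Fc1ccc(-c2ccc(-c3ccc(-c4nc5ccccc5[nH]4)cc3)cc2)cc1` gives 29700 nM
- compound 3 `Oc1ccc(-c2ccc(-c3ccc(-c4nc5ccccc5[nH]4)cc3)cc2)cc1` gives 33300 nM

Compound 3 sits level with compound 2, within the scatter, and compound 1 lies lower, beyond the scatter. The difference dimethylamino in place of hydroxy on an aromatic carbon leading to compound 4 `CN(C)c1ccc(-c2ccc(-c3ccc(-c4nc5ccccc5[nH]4)cc3)cc2)cc1` is dimethylamino in place of hydroxy on an aromatic carbon, para to a large group. Among the measured compounds shown here, the only measured step is a 1.1-fold higher number from compound 2 to compound 3 (0.05 log units; within the scatter) and it says little about this change. Although its core differs from that of compound 4, compound 1 also carries dimethylamino, and its 7110 nM suggests a lower number. The expected step is a 3.0-fold lower number from compound 3 to compound 4 (0.48 log units; beyond the scatter) in this assay, with wide uncertainty. For compound 4 the estimate is 11000 nM with 4500 nM to 30000 nM as the expected range.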

Compound 4, concentration for 50% growth inhibition: 100000 nM
Compound 4: middle estimate off by 9.1-fold (0.96 log units), on the low side; measured number above the stated range.
By their numbers in this assay, from the lowest: compound 1; then compounds 2 and 3 (each within the scatter of the next); then compound 4.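

In this assay, dimethylamino at this place, para to a large group, does not lower the number: a 3.0-fold higher number from compound 3 to compound 4 (0.48 log units; beyond the scatter) and a 3.4-fold higher number from compound 2 to compound 4 (0.53 log units; beyond the scatter) both run upward. Among the compounds shown here, the methyl on the core carries more weight than the dimethylamino group alone, with a 14-fold higher number from compound 1 to compound 4 (1.15 log units; beyond the scatter) as the largest step so far. Nothing measured here accounts for these steps.

Going by these compounds, it remains open how a plain amino group or a methoxy group would behave at this place. On these data alone, it is also open whether the methyl on the core would lower the numbers of compound 2 and compound 3.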